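The source may hold more compounds than are shown below. What is called first, only, known or untested is meant among the compounds shown, and "the series" means these compounds.

Three esters of one shared core have been tested in a functional assay on the whole organism (strain Wistar albino) for inhibition, with Rattus norvegicus as the target, read by paw edema, with stated times of 30 min and 3 h, at a dose of 20 mg/kg by the oral route; a lower number here means less inhibition, a higher number more inhibition at the dose given (going by the name of the read-out). Compound 1 `Cc1cc(=O)oc2cc(OC(=O)CNc3ccccc3[N+](=O)[O-])ccc12` gives 15.9%. Compound 2 `Cc1cc(=O)oc2cc(OC(=O)CNc3ccccc3Cl)ccc12` gives 12.8%. Compound 3 `Cc1cc(=O)oc2cc(OC(=O)CNc3ccc(Cl)cc3)ccc12` gives 15.9%, which is level with compound 1 at the digits reported, and both sit together at the top of the three numbers, with compound 2 the furthest away, though all three values lie within the scatter of one another. The change from compound 2 to compound 1 is nitro in place of chloro on an aromatic carbon, and it made a number 3.1 percentage points higher from compound 2 to compound 1 (within the scatter). The two cores differ as 4-chlorophenyl in place of 2-chlorophenyl on an amine nitrogen, a change that made a number 3.1 percentage points higher from compound 2 to compound 3 (within the scatter).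

Compound 4 `Cc1cc(=O)oc2cc(OC(=O)CNc3ccc([N+](=O)[O-])cc3)ccc12` has not yet been measured in this assay. It differs from compound 3 by nitro in place of chloro on an aromatic carbon. Among the measured compounds shown here, this is the same kind of change as the one from compound 2 to compound 1, but the place is not the same: there the nitro group stands ortho to a large group, here para to a large group. Because the earlier step was a number 3.1 percentage points higher from compound 2 to compound 1 (within the scatter), a step of a number 2.1 percentage points higher from compound 3 to compound 4 (within the scatter) is expected. Compound 4 is therefore estimated at 18%, between 8% and 28%.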

Compound 4, a percentage reported as inhibition, in the whole organism at one dose (the size of the read-out at that dose, not a potency): 20.2%
Compound 4: middle estimate off by 2.2 percentage points, on the low side; the measured number falls inside the stated range.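

Nitro in place of chloro has now been seen on two cores in this assay, and the new case reads a number 4.3 percentage points higher from compound 3 to compound 4 (within the scatter). Set beside the earlier case, the change carried over from one core to the other with no difference that can be told apart: the same change on two cores in this assay, a number 3.1 percentage points higher (within the scatter) from compound 2 to compound 1 and a number 4.3 percentage points higher (within the scatter) from compound 3 to compound 4, 1.2 percentage points apart, within the scatter of two such steps. Each step on its own lies within the scatter, however, so the pair does not show that nitro in place of chloro has any real effect on the read-out, only that nothing separates the two cores, and two cores cannot speak for the whole series.

The compounds shown leave open what a methoxy group, an amine or a carboxylic acid would give in place of the nitro or chloro group, and what a plain unsubstituted phenyl would give as a point of reference. They also leave open what a longer chain would do in place of the one linking the ester to the amine nitrogen.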